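The source may report more compounds than this note shows. Statements on the series, on what has been measured and on what is new or still open speak of the compounds shown alone.

In a functional assay (Nicotiana tabacum) (a lower number here means a stronger inhibitor, a higher number a weaker inhibitor), compound 1 `CSc1nc(Nc2ccc(Cl)cc2)c2cccnc2n1` gives 8510 nM and compound 2 `COc1ccc(Nc2nc(SC)nc3ncccc23)cc1` gives 9420 nM as its reading, so compound 2 stands level with compound 1 within the scatter. The next structure, compound 3 `CSc1nc(Nc2ccc(C(C)=O)cc2)c2cccnc2n1`, keeps the shared core and carries acetyl in place of methoxy on an aromatic carbon, para to a large group, the change being acetyl in place of methoxy on an aromatic carbon at that one place. Compound 1 and compound 2 differ at the same carbon, by methoxy in place of chloro, and that single measured step is a 1.1-fold higher number from compound 1 to compound 2 (0.04 log units; within the scatter) and nothing more. Among the measured compounds shown here, it is the only evidence that bears on the new change. For the measured compounds named here, no acetyl compound has been measured, so the data give no direct precedent and leave either direction open. On that one step, no shift beyond the scatter is expected in this assay for the new group. The estimate means a 1.0-fold lower number from compound 2 to compound 3 (0.02 log units; within the scatter) as the expected step. Compound 3 is estimated at 9000 nM with an expected range from 3000 nM to 27000 nM for its reading.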

Compound 3, half-maximal inhibitory concentration: 8960 nM
Compound 3: the middle estimate sits 1.0-fold (0.00 log units) above what was measured, within the range that was stated.
By their numbers in this assay, from the lowest: compounds 1, 3 and 2 (each within the scatter of the next).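

With compound 3, the carbon that carried chloro and methoxy now carries a third group, and in this assay the new step is a 1.1-fold lower number from compound 2 to compound 3 (0.02 log units; within the scatter), while the step from the chloro compound is a 1.1-fold higher number from compound 1 to compound 3 (0.02 log units; within the scatter). Before this, the position rested on a single comparison; now all three pairs among compounds 1, 2 and 3 stand within the scatter, and this holds for acetyl, which has 3 heavy atoms against 2 for methoxy and a double bond outside aromatic rings. Nothing measured here offers an explanation for how closely the three readings agree.

What these compounds leave open is whether this carbon stays as flat with a group of another kind, such as an amine, a carboxylic acid or a longer chain, since chloro, methoxy and acetyl span only a narrow set of groups. The shared core is the same in all three compounds, so they also cannot say whether a change elsewhere in the structure would move the reading in this assay beyond the scatter.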